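Swapping the Aryl Group on the Triazole of Compound 1

The source may hold more compounds than are shown below. What is called first, only, known or untested is meant among the compounds shown, and "the series" means these compounds.

Compound 1 `COc1ccc([C@@H]2C/C(=N/OCc3cn(-c4ccc(Cl)cc4C)nn3)c3cc(CC=C(C)C)c(OC)cc3O2)cc1` gives 49%
Compound 2 `CCCCOc1ccc([C@@H]2CC(=O)c3cc(CC=C(C)C)c(OC)cc3O2)cc1` gives 48%

In a functional assay on PC-3 cells (Homo sapiens) for inhibition, read by sulforhodamine B assay, with a stated time of 48 h, tested at 50 uM (a higher number here means more inhibition of growth at the concentration tested, a lower number less inhibition of growth), compound 1 gives 49% and compound 2 gives 48% so the two stand level within the scatter. Compound 3 `COc1ccc([C@@H]2C/C(=N/OCc3cn(-c4ccccc4CO)nn3)c3cc(CC=C(C)C)c(OC)cc3O2)cc1` has 2-(hydroxymethyl)phenyl in place of 4-chloro-2-methylphenyl on an aromatic nitrogen and has not yet been measured. Among the compounds with values here, no measured pair shows a step of this kind, so only a tentative expectation is possible in this assay of a modest fall, slightly beyond the scatter. The expected change is a number 12 percentage points lower from compound 1 to compound 3 (beyond the scatter) with wide uncertainty. For compound 3 the estimated value is 37% with an expected range from 18% to 55% around it.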

Compound 3, percent growth inhibition at one concentration: 100%
For compound 3 the middle estimate is 63 percentage points below the measured one, and the stated range ends below it.
By their numbers in this assay, from the lowest: compounds 2 and 1 (each within the scatter of the next); then compound 3.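

In this assay, within the data shown here, the step of a number 51 percentage points higher from compound 1 to compound 3 (beyond the scatter) shows that the aryl group on this aromatic nitrogen strongly affects growth inhibition at the concentration tested, which no earlier pair could show. The swap replaces 4-chloro-2-methylphenyl with 2-(hydroxymethyl)phenyl, so it removes the chlorine and adds a hydrogen-bond donor and acceptor in a single step. Nothing measured here accounts for the rise.

As far as these compounds go, whether the hydroxymethyl group or the loss of chlorine matters more remains open. So does how an aminomethyl or a carboxylic acid group would read on the same ring.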